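From trifluoromethyl to (dimethylamino)methyl on compound 1

The compounds below may be only part of what the source reports. "The series", "measured", "known", "first", "only" and "open" are said of these compounds alone.

For the measured compounds named here, in an ADME assay for pharmacokinetics, read by LC-MS, in phosphate buffer, with a stated time of 120 min, at pH 7.4, tested at 1 uM, in the presence of a further agent that is not named here (on this read-out higher numbers stand for a longer-lived compound and lower numbers for a shorter-lived compound), compound 1 `C=C(C(=O)Nc1ccccc1)C(F)(F)F` gives 0.25 h, the lowest of the numbers measured so far. Its nearest neighbour, compound 3 `O=C(/C=C/CN1CCCCC1)Nc1ccccc1`, gives 2.95 h, a number clearly higher and beyond the scatter. Compound 2 `O=C(O)C/C=C/C(=O)Nc1ccccc1` gives > 8.53 h, and this is a limit of the assay rather than a number.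

Compound 4 `C=C(CN(C)C)C(=O)Nc1ccccc1` has not been measured yet. It differs from compound 1 by one change ((dimethylamino)methyl in place of trifluoromethyl on a double-bonded chain carbon bound to a carbonyl carbon), with (dimethylamino)methyl in place of trifluoromethyl on a double-bonded chain carbon bound to a carbonyl carbon.

Going by the values given here, the only measured step that bears on this is an at least 2.8-fold lower number from compound 2 to compound 3 (0.46 log units; beyond the scatter), with piperidin-1-yl in place of carboxy on a saturated chain carbon bound to a double-bonded chain carbon. It starts from a limit and concerns a different place, so it guides only loosely. Compound 3 carries the nearest measured match to the entering group and gives 2.95 h, so a rise beyond the scatter is expected in this assay. The expected change is a 6.0-fold higher number from compound 1 to compound 4 (0.78 log units; beyond the scatter). For compound 4 the estimate is 1.5 h, with an expected range of 0.4 h to 6 h.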

Compound 4, half-life: < 0.0334 h
Compound 4: a limit, no number; the forecaster's own chance of this, stated with the estimate: 5%; middle value at least 44-fold (1.65 log units) away from the limit.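

At this place, on a double-bonded chain carbon bound to a carbonyl carbon, (dimethylamino)methyl in place of trifluoromethyl gives an at least 7.4-fold lower number from compound 1 to compound 4 (0.87 log units; beyond the scatter) in this assay. For the compounds shown here, until now the only step read lay at a different place, so this is the first sign that the group on this carbon can move the half-life downward from compound 1, which gives 0.25 h. The reading for compound 4 is a limit of the assay and not a number: the limit of < 0.0334 h in this assay, at which 1 of the 4 values shown sits.

One step at this place cannot separate the effect of gaining (dimethylamino)methyl from that of losing trifluoromethyl. It remains open what a plain methyl group, a carboxylic acid or a longer chain ending in an amine would give on this same carbon, and these compounds show no cause for the fall.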